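The source may hold more compounds than are shown below. What is called first, only, known or untested is meant among the compounds shown, and "the series" means these compounds.

Compound 1 `Cc1cc(-c2ccc(F)cc2)c(S(C)(=O)=O)cc1C(=O)N=C(N)N`: in a functional assay for inhibition of sodium/hydrogen exchanger (Oryctolagus cuniculus) (a lower number here means a stronger inhibitor, a higher number a weaker inhibitor), compound 1 gives 36 nM.
Compound 2 `Cc1cc(-c2ccccc2)c(S(C)(=O)=O)cc1C(=O)N=C(N)N`: compound 2 gives 19 nM.
Compound 3 `Cc1cc(Sc2cccc(Cl)c2)c(S(C)(=O)=O)cc1C(=O)N=C(N)N`: compound 3 gives 37 nM.

Compound 3 carries the largest of the three numbers, yet it is not set apart from the other two: the steps of a 1.0-fold higher number from compound 1 to compound 3 (0.01 log units; within the scatter) and a 1.9-fold higher number from compound 2 to compound 3 (0.29 log units; within the scatter) both lie within the scatter, as does a 1.9-fold lower number from compound 1 to compound 2 (0.28 log units; within the scatter). All three compounds share one core and differ only in the group attached to one aromatic carbon, and none of those exchanges moved the number beyond the scatter.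

Compound 4 `Cc1cc(Sc2ccncc2)c(S(C)(=O)=O)cc1C(=O)N=C(N)N` takes the next step from compound 3: pyridin-4-yl in place of 3-chlorophenyl on a sulfur. Among the measured compounds shown here, no measured pair exchanges the ring on the sulfur for one containing a ring nitrogen, so there is no direct precedent. The closest comparisons, the exchanges among compounds 1, 2 and 3, all stayed within the scatter, which suggests the same here. The expectation for compound 4 is therefore a step of a 1.4-fold higher number from compound 3 to compound 4 (0.13 log units; within the scatter), that is, no change beyond the scatter. Compound 4 is estimated at 50 nM, with a range from 15 nM to 160 nM.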

Compound 4, half-maximal inhibitory concentration: 13 nM
For compound 4 the middle estimate is 3.8-fold (0.59 log units) above the measured one; measured number outside the range, below it.
By their numbers in this assay, from the lowest: compounds 4, 2, 1 and 3 (each within the scatter of the next, the first and the last beyond it).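

Among the compounds shown here, exchanging the ring on the sulfur is the first change at this position to move the number beyond the scatter: in this assay, pyridin-4-yl in place of 3-chlorophenyl gives a 2.8-fold lower number from compound 3 to compound 4 (0.45 log units; beyond the scatter). The (pyridin-4-yl)sulfanyl group also separates from 4-fluorophenyl, with a 2.8-fold lower number from compound 1 to compound 4 (0.44 log units; beyond the scatter), but not from phenyl, where a 1.5-fold lower number from compound 2 to compound 4 (0.16 log units; within the scatter) stays within the scatter, so the gain is modest and holds against only two of the three earlier groups. No measurement shown here accounts for the shift.

The step from compound 3 to compound 4 removes the chlorine and brings in the ring nitrogen together, leaving open which of the two matters. Also open, as far as these compounds go, is how a plain phenyl or a pyridin-3-yl on the sulfur would compare, or an amine in place of the whole sulfur-linked group.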